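Benzyl in Place of Propargyl on a Cytotoxicity Read-out

This account rests on a few compounds, and the source may have more. Where it says the series, first, only, none or still open, it means among the compounds named here.

Compound 1 `O=C1c2ccccc2N(COCc2ccccc2)S(=O)(=O)N1Cc1ccccc1`: in a functional assay on HEL cells (Homo sapiens) (on this read-out higher numbers stand for lower toxicity in this test and lower numbers for higher toxicity in this test), compound 1 gives > 50 ug/mL, which is a limit of the assay and not a number.
Compound 2 `C#CCOCN1c2ccccc2C(=O)N(Cc2ccccc2)S1(=O)=O`: in this assay compound 2 gives > 50 ug/mL, again a limit and not a number.
Going by the values given here, compound 3 `C#CCOCN1C(=O)c2ccccc2NS1(=O)=O`: in this assay compound 3 gives 169 ug/mL, the only number among the three.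

Compound 1 and compound 2 differ by phenyl in place of ethynyl on a saturated chain carbon bound to an oxygen on a saturated carbon, and the step that the two limits leave unreadable from compound 2 to compound 1 cannot be sized, since both ends sit at the limit of > 50 ug/mL in this assay, at which 2 of the 3 values shown sit. Compound 4 `O=C1c2ccccc2NS(=O)(=O)N1COCc1ccccc1`, not yet measured, differs from compound 3 by phenyl in place of ethynyl on a saturated chain carbon bound to an oxygen on a saturated carbon, the same change, at the same place, as from compound 2 to compound 1. How the core of compound 3 differs from that of compound 2 is not broken down here.

With the measured step unreadable, the expectation for compound 4 rests on compound 3 alone, whose value is 169 ug/mL. Compound 4 is therefore expected to give about 150 ug/mL in this assay, between 40 ug/mL and 500 ug/mL, a step of a 1.1-fold lower number from compound 3 to compound 4 (0.05 log units; within the scatter) that is estimated to stay within the usual scatter.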

Compound 4, half-maximal cytotoxic concentration: 148 ug/mL
Estimate against measurement, compound 4: 1.0-fold (0.01 log units) above, and the stated range covers the measured number.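

Benzyl in place of propargyl on the core of compound 3 comes in this assay to a 1.1-fold lower number from compound 3 to compound 4 (0.06 log units; within the scatter), so on this core the change leaves no difference that can be told from the scatter. On the core of compound 2 the same change gives a step that cannot be read, since compound 1 and compound 2 both stand at a limit and not at a number: the limit of > 50 ug/mL in this assay, at which 2 of the 4 values shown sit. The result therefore rests on one readable pair, and it does not show that the change behaves alike on both cores, only that nothing in the two limits contradicts this.

The compounds shown leave open whether a readable step would appear on the core of compound 2 if its values could be given as numbers. They also leave open how a different group on a saturated chain carbon bound to an oxygen on a saturated carbon, such as an amine, a carboxylic acid or a longer chain, would read in this assay.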